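The compounds below may be only part of what the source reports. "The series", "measured", "known", "first", "only" and "open" are said of these compounds alone.

In an ADME assay on L6 cells (Rattus norvegicus) for cytotoxicity, read by fluorescence, with a stated time of 72 h (on this read-out lower numbers stand for stronger inhibition and higher numbers for weaker inhibition), compound 2 (`CCN(CC)CC(=O)NC1CC2(N3CCN(C)CC3)CC(c3ccccc3)C1C(c1ccccc1)C2`) gives 26400 nM. Compound 1 (`CN1CCN(C23CC(NC(=O)CCN4CCCC4)C(C(c4ccccc4)C2)C(c2ccccc2)C3)CC1`) gives 42200 nM, and these two values, the only ones measured so far, lie within the scatter of each other. Compound 3 (`CN1CCN(C23CC(NC(=O)CN4CCCCC4)C(C(c4ccccc4)C2)C(c2ccccc2)C3)CC1`) differs from compound 2 in one place: piperidin-1-yl in place of diethylamino on a saturated chain carbon bound to a carbonyl carbon. Put simply, piperidin-1-yl stands in place of diethylamino on a saturated chain carbon bound to a carbonyl carbon. Among the compounds with values here, the one measured step that bears on this is a 1.6-fold lower number from compound 1 to compound 2 (0.20 log units; within the scatter), which also exchanges the group on such a chain carbon. On that single step, no change beyond the scatter is expected in this assay. The estimated step is a 1.1-fold higher number from compound 2 to compound 3 (0.06 log units; within the scatter). The expected value for compound 3 is 30000 nM, with an estimated range of 15000 nM to 60000 nM.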

Compound 3, half-maximal inhibitory concentration: 22100 nM
Compound 3: middle estimate off by 1.4-fold (0.13 log units), on the high side; measured number inside the range.
By their numbers in this assay, from the lowest: compounds 3, 2 and 1 (each within the scatter of the next).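

In this assay, piperidin-1-yl in place of diethylamino on a saturated chain carbon bound to a carbonyl carbon adds a six-membered ring and gives a 1.2-fold lower number from compound 2 to compound 3 (0.08 log units; within the scatter), so closing the open amine into a ring brings no change that can be told from the scatter. Piperidin-1-yl in place of (pyrrolidin-1-yl)methyl gives a 1.9-fold lower number from compound 1 to compound 3 (0.28 log units; within the scatter), and with this second step also within the scatter, these three amine groups cannot be told apart at this place. No measurement is available that could explain this result.

From the compounds shown here alone, it remains open whether a group of another kind on this carbon, such as morpholin-4-yl or a carboxylic acid, would move the number beyond the scatter.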